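This account rests on a few compounds, and the source may have more. Where it says the series, first, only, none or still open, it means among the compounds named here.

In an ADME assay on HEp-2 cells (Homo sapiens) for cytotoxicity, read by MTT assay, with a stated time of 72 h (on this read-out lower numbers stand for stronger inhibition and higher numbers for weaker inhibition), compound 3 `COCOc1cc(C2=C(c3cc(OC)c(OC)c(OC)c3)C(=O)CC2O[SiH2]C(C)(C)C)ccc1OC` gives 12 ug/mL and compound 1 `COc1ccc(OC)c(C2=C(c3cc(OC)c(OC)c(OC)c3)C(=O)CC2O[SiH2]C(C)(C)C)c1` gives 19 ug/mL, two values within the scatter of each other. The step between them, a 1.6-fold lower number from compound 1 to compound 3 (0.20 log units; within the scatter), exchanges one aryl group for another and so leaves the read-out unresolved. Compound 4 `COc1ccc(C2=C(c3cc(OC)c(OC)c(OC)c3)C(=O)CC2O[SiH2]C(C)(C)C)cc1O` differs from compound 3 in one place: hydrogen in place of methoxymethyl on an oxygen on an aromatic ring. Hydrogen stands in place of methoxymethyl on an oxygen on an aromatic ring, turning methoxymethoxy to hydroxy. Within the data shown here, no measured step makes this change by itself, so the step above offers no direct guide to its size. Compound 2 `COc1ccc(C2=C(c3cc(OC)c(OC)c(OC)c3)C(=O)CC2O)cc1O` also carries the 3-hydroxy-4-methoxyphenyl group, and its < 1 ug/mL is a limit of the assay. That single limit is the only basis for expecting a lower number for compound 4, and it supports only a cautious expectation. The expected change in this assay is therefore a moderate one toward a lower number, a 2.4-fold lower number from compound 3 to compound 4 (0.38 log units; beyond the scatter). For compound 4 the estimated value is 5 ug/mL, with an expected range from 1.5 ug/mL to 14 ug/mL.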

Compound 4, half-maximal inhibitory concentration: 14.5 ug/mL
Beside the measured number, compound 4's estimate is 2.9-fold (0.46 log units) below it; the measured number lies above the stated range.
By their numbers in this assay, from the lowest: compounds 3, 4 and 1 (each within the scatter of the next). At a limit, below all of these: compound 2.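

In this assay, the aryl groups of the silicon-bearing compounds are not separated by the read-out, since hydroxy and methoxymethoxy give a 1.2-fold higher number from compound 3 to compound 4 (0.08 log units; within the scatter), and 3-hydroxy-4-methoxyphenyl and 2,5-dimethoxyphenyl give a 1.3-fold lower number from compound 1 to compound 4 (0.12 log units; within the scatter). With 3-hydroxy-4-methoxyphenyl held constant, the difference appears at another place, where a group of 5 heavy atoms (4 carbon, 1 silicon; no ring) stands in place of a hydrogen atom on an oxygen on a saturated carbon: an at least 14-fold higher number from compound 2 to compound 4 (1.16 log units; beyond the scatter). That step is measured against a value that is a limit, not a number: the limit of < 1 ug/mL in this assay, at which 1 of the 4 values shown sits.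

From the compounds shown here alone, how far compound 2 lies past its limit remains open, as does whether methoxymethoxy or 2,5-dimethoxyphenyl would matter with hydrogen on that oxygen on a saturated carbon. Also open, going by these compounds, is how an amine or a longer carbon chain would read at that oxygen.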